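Propyl to Cyclopropyl on the Amide Carbonyl

A few compounds are considered here, and "the series" means these few. Any claim that something is new, unique, unknown or untested is made for them only; others in the source may bear on it.

Compound 2 `CCCC(=O)NCCC(=O)c1cc(OC)ccc1N` and compound 1 `CCC(=O)NCCC(=O)c1cc(OC)ccc1N` share one core and differ only by a methyl on the chain. In an assay for inhibition of Nitric oxide synthase, inducible (Homo sapiens), read by scintillation counting, with a stated time of 30 min, tested at 1 mM (on this read-out higher numbers stand for more inhibition at the one concentration tested (going by the name of the read-out) and lower numbers for less inhibition), compound 1 gives 0.24%, and compound 2 gives 7.35%; the step of a number 7.1 percentage points higher from compound 1 to compound 2 (within the scatter) lies within the usual scatter, so the two numbers cannot be told apart, and both sit near the bottom of the scale.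

Compound 3 `COc1ccc(N)c(C(=O)CCNC(=O)C2CC2)c1` is the next step from compound 2: cyclopropyl in place of propyl on a carbonyl carbon. Going by the values given here, the only measured step, the one from compound 1 to compound 2, is small and sits on the same amide side chain; nothing measured so far moves the read-out beyond the scatter. The expected step of a number 2.4 percentage points lower from compound 2 to compound 3 (within the scatter) is therefore none beyond the scatter. Compound 3 is estimated at 5%, with a range from -5% to 20%.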

Compound 3, a percentage reported as inhibition, at one concentration (the size of the read-out at that concentration, not a potency): 2.66%
For compound 3 the middle estimate is 2.3 percentage points above the measured one; the measured number falls inside the stated range.
By their numbers in this assay, from the lowest: compounds 1, 3 and 2 (each within the scatter of the next).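

Putting a ring at this position does not register: on a carbonyl carbon whose other neighbour is an amide-type nitrogen, cyclopropyl in place of propyl gives a number 4.7 percentage points lower from compound 2 to compound 3 (within the scatter) in this assay and cyclopropyl in place of ethyl gives a number 2.4 percentage points higher from compound 1 to compound 3 (within the scatter) on the same read-out. Cyclopropyl and propyl carry the same count of carbons, so the ring itself is the new feature here, and it leaves all three compounds indistinguishable near the bottom of the scale at the one concentration tested. No measurement available here explains this flat result.

From the compounds shown here alone, whether a longer chain, a phenyl ring or a carboxylic acid on this carbonyl carbon would move the number beyond the scatter stays open. So does whether any change to the shared core would do so.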